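The source may report more compounds than this note shows. Statements on the series, on what has been measured and on what is new or still open speak of the compounds shown alone.

The measured compounds:
Compound 1, `Nc1cc(N)c2nc(-c3ccccc3)c(NCc3ccc(Cl)c(Cl)c3)nc2c1`: 24000 nM
Compound 2, `Nc1cc(N)c2nc(-c3ccccc3)c(Sc3ccc(Cl)c(Cl)c3)nc2c1`: 38900 nM

In a functional assay on OVCAR-5 cells (Homo sapiens) for inhibition, read by sulforhodamine B assay, with a stated time of 48 h (on this read-out lower numbers stand for stronger inhibition of growth and higher numbers for weaker inhibition of growth), compound 1 gives 24000 nM, the smaller of the two numbers shown, though compound 2 at 38900 nM lies within the scatter of it, so the two are not told apart. Compound 3, `COc1ccc(CNc2nc3cc(N)cc(N)c3nc2-c2ccccc2)cc1`, is not yet measured. It differs from compound 1 as 4-methoxyphenyl in place of 3,4-dichlorophenyl on a saturated chain carbon bound to a nitrogen on an aromatic ring. Among the measured compounds shown here, no measured pair shows this change, so nothing supports a step beyond the scatter in either direction. Compound 3 is therefore expected to give 30000 nM, within 10000 nM to 90000 nM. The expected step of a 1.3-fold higher number from compound 1 to compound 3 (0.10 log units; within the scatter) amounts to no real change.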

Compound 3, concentration for 50% growth inhibition: 20900 nM
For compound 3 the middle estimate is 1.4-fold (0.16 log units) above the measured one; measured number inside the range.
By their numbers in this assay, from the lowest: compounds 3, 1 and 2 (each within the scatter of the next).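

In this assay, 4-methoxyphenyl in place of 3,4-dichlorophenyl on a saturated chain carbon bound to a nitrogen on an aromatic ring gives a 1.1-fold lower number from compound 1 to compound 3 (0.06 log units; within the scatter) and so lies within the scatter. This is the only pair shown that varies this position, and the read-out does not tell the two groups apart, although the chlorine atoms are gone and an oxygen has entered. No measurement at hand bears on this result. Open, on these data alone, is whether an amine, a carboxylic acid or a longer chain at this place would separate from compound 1.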